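The compounds below may be only part of what the source reports. "The series", "measured", "known", "first", "only" and "open" are said of these compounds alone.

Three compounds built on a shared core were tested in an ADME assay on KB cells (Homo sapiens) for cytotoxicity, read by MTT assay, with a stated time of 72 h; on this read-out lower numbers stand for stronger inhibition and higher numbers for weaker inhibition. Compound 1 `COc1ccc(C2=C(c3cc(OC)c(OC)c(OC)c3)C(=O)CC2O[SiH2]C(C)(C)C)cc1OC` gives only a limit in this assay, > 100 ug/mL, not a number. Compound 2 `COc1ccc(C2=C(c3cc(OC)c(OC)c(OC)c3)C(=O)C(OC(C)=O)C2)cc1O` gives 35 ug/mL in this assay. Compound 3 `C=CCOc1cc(C2=C(c3cc(OC)c(OC)c(OC)c3)C(=O)C(O)C2)ccc1OC` likewise gives only a limit, > 100 ug/mL, in this assay. Compound 3 therefore stands at the limit of > 100 ug/mL in this assay, at which 2 of the 3 values shown sit, with no number of its own. Compound 4 `COc1ccc(C2=C(c3cc(OC)c(OC)c(OC)c3)C(=O)C(O)C2)cc1NC(=O)c1ccccc1` differs from compound 3 by one change: benzamido in place of allyloxy on an aromatic carbon. Going by the values given here, no measured pair here shows what this kind of change does, so the expectation for compound 4 rests on compound 3 alone. The step of an at least 1.2-fold lower number from compound 3 to compound 4 (0.09 log units; that floor lies within the scatter) is expected to be small, probably none beyond the scatter, with a modest gain possible. Compound 4 is expected to give about 80 ug/mL, within 30 ug/mL to 200 ug/mL, and may again return only a limit.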

Compound 4, half-maximal inhibitory concentration: > 100 ug/mL
Compound 4: a limit, no number; the forecaster's own chance of this, stated with the estimate: 50%; middle value at least 1.2-fold (0.09 log units) from the limit.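

Going by these compounds alone, compound 3 and compound 4 each give only a limit, not a number, in this assay, so no step between them can be read: the limit of > 100 ug/mL in this assay, at which 3 of the 4 values shown sit. As far as these compounds go, whether benzamido in place of allyloxy changes cytotoxicity at all stays open.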